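This account rests on a few compounds, and the source may have more. Where it says the series, first, only, none or still open, it means among the compounds named here.

Of the compounds shown here, three have been tested in a functional assay on MCF7 cells (Homo sapiens) for cytotoxicity, read by MTT assay, with a stated time of 72 h; a higher number here means a weaker inhibitor of growth, a lower number a stronger inhibitor of growth. Compound 1 `N#CSc1nc2ccccc2s1` gives 67600 nM. Compound 2 `CSc1ccc2ccccc2n1` reaches only a limit of the assay, > 100000 nM. Compound 3 `O=C1c2ccccc2C(=O)N1CS` likewise reaches only a limit of the assay, > 100000 nM. Compound 3 therefore stands at the limit of > 100000 nM in this assay, at which 2 of the 3 values shown sit, so no number is known for it, only that it lies at the edge of what the assay can report.

Compound 4 `N#C[Se]CN1C(=O)c2ccccc2C1=O` has not yet been measured. It differs from compound 3 by a group of 3 heavy atoms (1 carbon, 1 nitrogen, 1 selenium; no ring) in place of one sulfur atom, on a saturated chain carbon bound to an amide-type nitrogen in a ring. Going by the values given here, no pair of measured compounds shows this change, so no measured step tells what to expect from it. A move towards stronger growth inhibition seems possible because compound 1 gives 67600 nM, a number the assay could still resolve, whereas compound 3 did not reach one. The expected step in this assay is an at least 1.6-fold lower number from compound 3 to compound 4 (0.22 log units; that floor lies within the scatter). Compound 4 is estimated at 60000 nM, with a range from 20000 nM to 150000 nM.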

Compound 4, concentration for total growth inhibition: 56100 nM
For compound 4 the middle estimate is 1.1-fold (0.03 log units) above the measured one, within the range that was stated.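

In this assay, going by these compounds alone, putting the group of 3 heavy atoms (1 carbon, 1 nitrogen, 1 selenium) on the saturated chain carbon bound to an amide-type nitrogen in a ring gives a resolved number for the first time of phthalimide-free comparisons at this position: compound 4 gives 56100 nM. The change can be sized only as a floor, an at least 1.7-fold lower number from compound 3 to compound 4 (0.25 log units; that floor lies within the scatter). Compound 3 has a limit and not a number, so the real size of the step stays unknown: the limit of > 100000 nM in this assay, at which 2 of the 4 values shown sit.

On these data alone, it remains open whether the selenium or the nitrile matters more, as each enters together with the other in this single change. Also open, as far as these compounds go, is how an amine or a methylselanyl group on the same chain carbon would read in this assay.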